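A few compounds are considered here, and "the series" means these few. Any claim that something is new, unique, unknown or untested is made for them only; others in the source may bear on it.

Of the compounds shown here, three have been measured in a functional assay for antagonist activity at corticotropin-releasing factor receptor 1 (Rattus norvegicus); a higher number here means a weaker inhibitor, a lower number a stronger inhibitor. Compound 1 `CCC(C1CC1)n1c(=O)c(C)nc2c(-c3ccc(C)cc3C)ccnc21` gives 8.8 nM, compound 2 `CC[C@H](COC)n1c(=O)c(C)nc2c(-c3ccc(Cl)cc3Cl)ncnc21` gives 97 nM, and compound 3 `Cc1nc2c(-c3ccc(Cl)cc3Cl)ccnc2n(CC(C)C)c1=O` gives 3500 nM. Compound 3 therefore stands highest of the three numbers, its nearest neighbour being compound 2 and its furthest compound 1, and both of those gaps lie beyond the usual scatter of repeated measurements.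

Compound 4 `Cc1nc2c(-c3ccc(Cl)cc3Cl)ccnc2n(C(C)C(C)C)c1=O` has not yet been measured. It differs from compound 3 in one place: methyl in place of hydrogen on a saturated chain carbon bound to an aromatic nitrogen and a saturated chain carbon. Compounds 1 and 2 both carry a branched chain on the same aromatic nitrogen, and both return far lower numbers than compound 3, though no single-point comparison connects them to compound 3.

On that footing, the step from compound 3 to compound 4 in this assay is expected to be a fall, a 10-fold lower number from compound 3 to compound 4 (1.00 log units; beyond the scatter), clearly beyond the scatter. For compound 4 the estimate is 350 nM, with a range from 70 nM to 1800 nM.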

Compound 4, half-maximal inhibitory concentration: 380 nM
For compound 4 the middle estimate is 1.1-fold (0.04 log units) below the measured one; the measured number falls inside the stated range.
By their numbers in this assay, from the lowest: compound 1; then compound 2; then compound 4; then compound 3.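

In this assay, turning isobutyl into 1,2-dimethylpropyl gives a 9.2-fold lower number from compound 3 to compound 4 (0.96 log units; beyond the scatter), so a single added methyl on this saturated chain carbon is enough to shift the result. Earlier, compounds 1 and 2 could only hint that the chain on this aromatic nitrogen matters, since each differs from compound 3 in more than one place; this pair isolates one change at one position. Nothing measured here explains how the methyl produces this shift.

Going by these compounds, whether an ethyl, a hydroxymethyl or an amine on this same carbon would lower the number further, or raise it again, stays open. Also open, on these data alone, is whether the added methyl would have a similar effect if the dichlorophenyl group on the shared core were replaced by another group.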